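Compound 3 and the amine methyl

The source may report more compounds than this note shows. Statements on the series, on what has been measured and on what is new or still open speak of the compounds shown alone.

Going by the values given here, compound 3 `CC(C)C[C@H](NC(=O)CCN(C)C)c1cc(C(F)(F)F)ccc1N1CCN(C(=O)[C@H]2CSC[C@@H]2c2ccc(Cl)cc2)CC1` holds the lowest number so far in an assay on HEK293 cells for displacement of a labelled ligand from Melanocortin receptor 4 (Homo sapiens) (a lower number here means a stronger inhibitor, a higher number a weaker inhibitor), where compound 3 gives 130 nM. Compound 1 `CC(C)C[C@H](N)c1cc(C(F)(F)F)ccc1N1CCN(C(=O)[C@H]2CSC[C@@H]2c2ccc(Cl)cc2)CC1` gives 280 nM and compound 2 `CC(C)C[C@H](N)c1cc(Cl)ccc1N1CCN(C(=O)[C@H]2CCO[C@@H]2c2ccc(Cl)cc2)CC1` gives 280 nM; the two share that value. Among the compounds with values here, the single measured step, a 2.2-fold lower number from compound 1 to compound 3 (0.33 log units; beyond the scatter), concerns the (2-(dimethylamino)ethyl)carbonyl group placed on the amine nitrogen and was modest. Compound 4 `CNCCC(=O)N[C@@H](CC(C)C)c1cc(C(F)(F)F)ccc1N1CCN(C(=O)[C@H]2CSC[C@@H]2c2ccc(Cl)cc2)CC1` differs from compound 3 by hydrogen in place of methyl on an amine nitrogen. Within the data shown here, no measured step touches this nitrogen, so nothing bears directly on the change; the expectation is a number near that of compound 3, a step of a 1.2-fold higher number from compound 3 to compound 4 (0.06 log units; within the scatter) that stays within the scatter. Compound 4 is therefore estimated at 150 nM, with a range from 70 nM to 330 nM.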

Compound 4, inhibition constant: 170 nM
Estimate against measurement, compound 4: 1.1-fold (0.05 log units) below; measured number inside the range.
By their numbers in this assay, from the lowest: compounds 3, 4, 1 and 2 (each within the scatter of the next, the first and the last beyond it).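

On an amine nitrogen, hydrogen in place of methyl leaves the number within the scatter (a 1.3-fold higher number from compound 3 to compound 4 (0.12 log units; within the scatter)), so in this assay this methyl is not required to keep compound 4 level with compound 3. The (2-(methylamino)ethyl)carbonyl group on the other amine nitrogen stays within the scatter (a 1.6-fold lower number from compound 1 to compound 4 (0.22 log units; within the scatter)), whereas the dimethylamino version lay beyond it (a 2.2-fold lower number from compound 1 to compound 3 (0.33 log units; beyond the scatter)). Nothing available explains this difference.

Open, from the compounds shown here alone, is whether a primary amine or a longer chain at the end of this group would keep the number. The series also leaves open how a carboxylic acid in place of the amine would read.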